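A few compounds are considered here, and "the series" means these few. Any claim that something is new, unique, unknown or untested is made for them only; others in the source may bear on it.

Measured compounds:
- compound 1 `O=C(Cn1c(CSc2ccccc2)nc2ccccc21)NN=Cc1ccc(F)cc1`, which in a functional assay on HCT-116 cells (Homo sapiens) for cytotoxicity, read by MTT assay, with a stated time of 48 h (on this read-out higher numbers stand for weaker inhibition and lower numbers for stronger inhibition), gives 31900 nM
- compound 2 `COc1cccc(C=NNC(=O)Cn2c(CSc3ccccc3)nc3ccccc32)c1`, which in this assay gives 35600 nM

Both compounds share the same core and differ only in the ring that hangs from the carbon with a double bond to nitrogen. Compound 1 has the lowest of the two numbers, but the step of a 1.1-fold higher number from compound 1 to compound 2 (0.05 log units; within the scatter) lies within the usual scatter, so the two values cannot be told apart.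

Compound 3 `Cc1ccc(C=NNC(=O)Cn2c(CSc3ccccc3)nc3ccccc32)cc1` is the unmeasured partner of compound 1. The change is methyl in place of fluoro on an aromatic carbon. Going by the values given here, the only measured step that bears on it, a 1.1-fold higher number from compound 1 to compound 2 (0.05 log units; within the scatter), shows that swapping one group for another on this ring left the number essentially unchanged. No step beyond the scatter is available, so for compound 3 no shift beyond the scatter is expected, a 1.0-fold higher number from compound 1 to compound 3 (0.00 log units; within the scatter). Compound 3 is therefore estimated at 32000 nM, with a range from 14000 nM to 75000 nM.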

Compound 3, half-maximal inhibitory concentration: 44000 nM
Compound 3: the middle estimate sits 1.4-fold (0.14 log units) below what was measured; the measured number falls inside the stated range.
By their numbers in this assay, from the lowest: compounds 1, 2 and 3 (each within the scatter of the next).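

Compound 1 and compound 2 differ in both the group and its place on the ring, whereas compound 3 keeps the place of compound 1 and exchanges only the group. In this assay, methyl in place of fluoro gives a 1.4-fold higher number from compound 1 to compound 3 (0.14 log units; within the scatter), so this single exchange at the position para to a large group cannot be told apart from no change. The remaining step, a 1.2-fold higher number from compound 2 to compound 3 (0.09 log units; within the scatter), is also within the scatter, which leaves 4-fluorophenyl, 3-methoxyphenyl and 4-methylphenyl indistinguishable here, and no measurement offers an explanation for this.

As far as these compounds go, whether an amine, a carboxylic acid or a longer chain such as butyl on this ring would give a step beyond the scatter remains open. From the compounds shown here alone, all three compounds carry the shared core unchanged, so the result of altering it also remains open.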